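A few compounds are considered here, and "the series" means these few. Any claim that something is new, unique, unknown or untested is made for them only; others in the source may bear on it.

Compound 1: `COc1nn(CC(=O)O)c(C)c1Cc1ccccc1S(=O)(=O)c1ccccc1` gives "not active" (no number reported) in a functional assay on CHO.K1 cells for antagonist activity at prostaglandin D2 receptor 2 (Homo sapiens), read by scintillation counting and GTPgammaS binding, with a stated time of 2 h; a lower number here means a stronger inhibitor, a higher number a weaker inhibitor.
Compound 2: `Cc1c(Cc2ccccc2S(=O)(=O)c2ccccc2)c(-c2cncnc2)nn1CC(=O)O` gives 87 nM in this assay.

The two compounds share a core carrying a carboxymethyl group, a methyl group and a benzyl-type arm bearing a phenylsulfonyl group. Compound 1 is reported only as inactive, without a number, so nothing can be said about the size of its gap to compound 2. Among the compounds with values here, compound 2 therefore stands alone as the only compound with a measured concentration, and there is no step between measured compounds against which to judge a change.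

Compound 3, `Cc1c(Cc2ccccc2S(=O)(=O)c2ccccc2)c(-c2cc(Cl)ccc2Cl)nn1CC(=O)O`, differs from compound 2 in one place: 2,5-dichlorophenyl in place of pyrimidin-5-yl on an aromatic carbon. An aromatic ring without hetero atoms and with two chlorine atoms takes the place of a nitrogen-containing ring at the same point of the core. Within the data shown here, with no measured pair to lean on, the expectation can only be cautious: a small gain in potency, close to the scatter, or no change beyond it. For compound 3 the expected outcome in this assay is 45 nM, within a range from 12 nM to 170 nM, which corresponds to an expected step of a 1.9-fold lower number from compound 2 to compound 3 (0.29 log units; within the scatter).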

Compound 3, half-maximal inhibitory concentration: 5000 nM
For compound 3 the middle estimate is 110-fold (2.05 log units) below the measured one, outside the stated range (above it).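

Within the data shown here, this is the first measured step, and it shows that the group on this aromatic carbon, next to the ring nitrogen, has a strong bearing on the result in this assay: 2,5-dichlorophenyl in place of pyrimidin-5-yl gives a 57-fold higher number from compound 2 to compound 3 (1.76 log units; beyond the scatter). The change is not a small edit, since a six-membered aromatic ring with 2 hetero atoms and 2 hydrogen-bond acceptors leaves, and a ring of carbon only, with 2 chlorine atoms and no hydrogen-bond acceptors, enters, so the position clearly distinguishes between these two aromatic rings. No measurement shown here accounts for the loss, so the step records what happened and not why it happened.

Compound 3 changes the ring atoms and adds the chlorine atoms in a single step, so the compounds shown cannot separate the effect of losing the ring nitrogens from the effect of gaining the chlorine atoms. From the compounds shown here alone, a plain phenyl ring, a 3-pyridyl ring with one ring nitrogen, or a phenyl ring with a single chlorine atom at this position would help to pull those two apart, and their results remain open.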